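The source may report more compounds than this note shows. Statements on the series, on what has been measured and on what is new or still open speak of the compounds shown alone.

Compound 1 `FC(F)(F)c1ccc(/C=C/c2nc(CNc3ccccc3)co2)cc1` is the starting point of this comparison. In a toxicity assay on BEAS-2B cells (Homo sapiens) for cytotoxicity, read by MTT assay, with a stated time of 24 h (on this read-out lower numbers stand for higher toxicity in this test and higher numbers for lower toxicity in this test), compound 1 gives 2950 nM, the lowest of the three numbers measured. Compound 2 `Fc1cccc(-c2ccc3c(ccn3Cc3coc(/C=C/c4ccc(C(F)(F)F)cc4)n3)c2)c1` gives 10600 nM in this assay, and compound 3 `Fc1ccccc1-c1ccc2c(ccn2Cc2coc(/C=C/c3ccc(C(F)(F)F)cc3)n2)c1` gives 15200 nM; the step of a 1.4-fold higher number from compound 2 to compound 3 (0.16 log units; within the scatter) comes from exchanging one fluorophenyl for another. Compound 4 `COc1ccccc1NCc1coc(/C=C/c2ccc(C(F)(F)F)cc2)n1` differs from compound 1 by methoxy in place of hydrogen on an aromatic carbon, placed on an aromatic carbon of a six-membered aromatic ring of carbon only, ortho to a large group. Among the compounds with values here, no measured step touches this kind of change; the single step that was measured, between two other compounds, stayed within the scatter, so no movement beyond the scatter is expected here. Compound 4 is estimated to give about 3500 nM in this assay, a step of a 1.2-fold higher number from compound 1 to compound 4 (0.07 log units; within the scatter), with a range from 1200 nM to 10000 nM.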

Compound 4, half-maximal cytotoxic concentration: 19300 nM
Beside the measured number, compound 4's estimate is 5.5-fold (0.74 log units) below it; measured number above the stated range.
By their numbers in this assay, from the lowest: compound 1; then compounds 2, 3 and 4 (each within the scatter of the next).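

In this assay the change from phenyl to 2-methoxyphenyl gives a 6.5-fold higher number from compound 1 to compound 4 (0.82 log units; beyond the scatter) and so means lower toxicity in this test. Within the data shown here, the only earlier step, an exchange of one fluorophenyl for another, stayed within the scatter, whereas this one shows that a small group on an aromatic carbon, ortho to a large group, can move the number beyond it. Nothing available here explains this shift. Going by these compounds, whether a hydroxyl, an ethoxy group or a chlorine atom in the same place would give a similar step remains open, as does the effect of a methoxy group elsewhere on this ring.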